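The compounds below may be only part of what the source reports. "The series", "measured", "known", "first", "only" and "open" are said of these compounds alone.

Of the compounds shown here, three built on one shared core have been tested in a functional assay on the whole organism with Rattus norvegicus as the target; on this read-out higher numbers stand for an effect only at larger amounts of compound and lower numbers for an effect already at smaller amounts. Compound 1, `C/N=C(\NC#N)NCCCCn1nc(-c2ccccc2)ccc1=O`, gives 38.5 mg/kg in this assay. Compound 2, `CC/N=C(\S)NCCCn1nc(-c2ccccc2)ccc1=O`, gives 88.2 mg/kg in this assay. Compound 3, `O=c1ccc(-c2ccccc2)nn1CCCCNC(=S)Nc1ccccc1`, gives no number in this assay but only a limit, > 100 mg/kg. That value is the limit of > 100 mg/kg in this assay, at which 1 of the 3 values shown sits. Among the numbers shown, compound 1 stands lowest: the step of a 2.3-fold higher number from compound 1 to compound 2 (0.36 log units; beyond the scatter) was modest, and the step of an at least 2.5-fold higher number from compound 1 to compound 3 (0.41 log units; beyond the scatter) was at least modest.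

Compound 4, `CN(C)/C(=N/CCCCn1nc(-c2ccccc2)ccc1=O)NC#N`, is the next compound to be measured. It differs from compound 1 in one place: a group of 8 heavy atoms (4 carbon, 4 nitrogen; no ring) in place of a group of 7 heavy atoms (3 carbon, 4 nitrogen; no ring), on a saturated chain carbon, four bonds along the chain from an aromatic nitrogen. Both measured steps away from compound 1 changed a group on the chain and gave higher numbers, and because the steps of a 2.3-fold higher number from compound 1 to compound 2 (0.36 log units; beyond the scatter) and an at least 2.5-fold higher number from compound 1 to compound 3 (0.41 log units; beyond the scatter) point the same way, a modest rise is expected for compound 4 as well. For compound 4 the expected step is a 1.4-fold higher number from compound 1 to compound 4 (0.15 log units; within the scatter). Compound 4 is therefore estimated at 55 mg/kg in this assay, with a range from 25 mg/kg to 120 mg/kg.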

Compound 4, dose for half-maximal effect: 52.9 mg/kg
For compound 4 the middle estimate is 1.0-fold (0.02 log units) above the measured one, within the range that was stated.
By their numbers in this assay, from the lowest: compounds 1, 4 and 2 (each within the scatter of the next, the first and the last beyond it). At a limit, above all of these: compound 3.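

In this assay, the group of 8 heavy atoms with 1 hydrogen-bond donor, in place of the group of 7 heavy atoms with 2 hydrogen-bond donors, gives a 1.4-fold higher number from compound 1 to compound 4 (0.14 log units; within the scatter) on this saturated chain carbon. The two earlier steps away from compound 1 went beyond the scatter, whereas this one does not, so at this position the loss of one hydrogen-bond donor goes with no difference that can be told apart from repeat-measurement noise. No measurement shown bears on why this swap leaves the read-out so close.

Going by these compounds, whether this holds for larger end groups, such as a piperidine ring or a diethylamine, remains open. So does the effect of a carboxylic acid at this place, or of a longer chain carrying the same group.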